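Thiophenyl Variation in a Benzamide Series: Predicting Compound 4

This account rests on a few compounds, and the source may have more. Where it says the series, first, only, none or still open, it means among the compounds named here.

The series shares one core, varied only at the aryl group on sulfur. In a functional assay on A-375 cells (Homo sapiens) for inhibition, read by CCK-8 assay, with a stated time of 72 h, tested at 8 uM (a higher number here means more inhibition of growth at the concentration tested, a lower number less inhibition of growth), compound 1 `Cc1ccc(SCc2ccc(C(=O)Nc3ccccc3N)cc2)cc1` gives 67%, compound 2 `Nc1ccccc1NC(=O)c1ccc(CSc2cccc(F)c2)cc1` gives 76.3%, and compound 3 `Cc1cc(C)cc(SCc2ccc(C(=O)Nc3ccccc3N)cc2)c1` gives 74.7%, the second highest of the three numbers. Compound 3 is nearest to compound 2 and furthest from compound 1, yet a number 1.6 percentage points lower from compound 2 to compound 3 (within the scatter) and a number 7.7 percentage points higher from compound 1 to compound 3 (within the scatter) both lie within the scatter, as does a number 9.3 percentage points higher from compound 1 to compound 2 (within the scatter). Compound 4 `Nc1ccccc1NC(=O)c1ccc(CSc2ccc(Cl)cc2)cc1` is reached by 4-chlorophenyl in place of 3,5-dimethylphenyl on a sulfur. Every measured change at the same sulfur position moved this assay by less than the scatter, so no step beyond it is expected, and a number 1.7 percentage points lower from compound 3 to compound 4 (within the scatter) is estimated. Compound 4 is therefore expected to give about 73%, with a range from 60% to 85%.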

Compound 4, percent growth inhibition at one concentration: 48.6%
Compound 4: middle estimate off by 24.4 percentage points, on the high side; the measured number lies below the stated range.
By their numbers in this assay, from the lowest: compound 4; then compounds 1, 3 and 2 (each within the scatter of the next).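

Within the data shown here, the aryl group on sulfur proves less forgiving in this assay than the earlier compounds suggested, with 4-chlorophenyl giving a number 26.1 percentage points lower from compound 3 to compound 4 (beyond the scatter) and a number 27.7 percentage points lower from compound 2 to compound 4 (beyond the scatter). Even the single change of chloro in place of methyl on an aromatic carbon gives a number 18.4 percentage points lower from compound 1 to compound 4 (beyond the scatter), so one substituent on this aryl ring can move the number beyond the scatter. No available evidence bears on this drop. Still open, on these data alone, is whether the drop is particular to chloro, or would recur with 3-chlorophenyl, 4-fluorophenyl or an aryl ring carrying an amine or a carboxylic acid.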